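Removing a chloro group from a tryptophan dioxygenase inhibitor

A few compounds are considered here, and "the series" means these few. Any claim that something is new, unique, unknown or untested is made for them only; others in the source may bear on it.

Of the compounds shown here, three sharing one core have been tested in an assay for inhibition of Tryptophan 2,3-dioxygenase (Homo sapiens), with stated times of 10 min and 60 min, tested at 100 uM; on this read-out higher numbers stand for a stronger effect at the one concentration tested and lower numbers for a weaker effect. Compound 1, `O=[N+]([O-])c1ccccc1CNc1cccc2[nH]ncc12`, gives 87% in this assay. Compound 2, `O=[N+]([O-])c1cc(Cl)ccc1CNc1cc(C(F)(F)F)cc2[nH]ncc12`, carries a chloro group and a trifluoromethyl group that compound 1 lacks, and in this assay compound 2 gives 93%. Compound 3, `COc1cc(CNc2cc(Br)cc3[nH]ncc23)c([N+](=O)[O-])cc1OC`, gives 95% in this assay. Compound 2 thus stands second highest of the three numbers, but its gap to compound 3 and its gap to compound 1 both lie within the usual scatter, so the three compounds cannot be ranked against one another.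

The next compound, compound 4, `O=[N+]([O-])c1ccccc1CNc1cc(C(F)(F)F)cc2[nH]ncc12`, differs from compound 2 in one place: hydrogen in place of chloro on an aromatic carbon. Compound 1, which also has hydrogen at that place, gives a number close to compound 2, so no step beyond the scatter is expected here. Compound 4 is expected to give 88% in this assay, within a range from 76% to 96%, which means an estimated step of a number 5 percentage points lower from compound 2 to compound 4 (within the scatter).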

Compound 4, a percentage reported as inhibition, at one concentration (the size of the read-out at that concentration, not a potency): 95%
For compound 4 the middle estimate is 7 percentage points below the measured one, and the stated range covers the measured number.
By their numbers in this assay, from the lowest: compounds 1, 2, 3 and 4 (each within the scatter of the next).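

In this assay hydrogen in place of chloro, on the aromatic carbon meta to a nitro group, comes with a number 2 percentage points higher from compound 2 to compound 4 (within the scatter) and so shows that this position can lose its chloro group with no change beyond the usual scatter of the read-out. Trifluoromethyl in place of hydrogen on an aromatic carbon comes with a number 8 percentage points higher from compound 1 to compound 4 (within the scatter) and so also leaves the read-out within that scatter, which means neither single change can be said to matter here. Nothing measured on these compounds speaks to what lies behind either step.

The compounds shown leave open what a group other than chloro or hydrogen, such as an amine or a carboxylic acid, would do at this position. With one concentration behind each number, any difference in potency among these compounds also stays open.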